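A methyl added to the pyridine of compound 3

A few compounds are considered here, and "the series" means these few. Any claim that something is new, unique, unknown or untested is made for them only; others in the source may bear on it.

Compound 3 `Cc1ccc(S(=O)(=O)N(CC(=O)NCc2ccc(Cl)cc2)c2cccnc2)cc1` stands, in a functional assay on CHO-K1 cells for antagonist activity at prostaglandin E2 receptor EP1 subtype (Homo sapiens), read by FLIPR and calcium flux (on this read-out higher numbers stand for weaker inhibition and lower numbers for stronger inhibition), only at a limit: compound 3 gives < 1450 nM, a limit rather than a number, the same limit as the limit of < 1450 nM in this assay, at which 1 of the 3 values shown sits. Compound 4 `Cc1ccc(S(=O)(=O)N(CC(=O)NCc2ccc(Cl)cc2)c2cccnc2C)cc1` differs from compound 3 by a single change, (methyl in place of hydrogen on an aromatic carbon), a methyl in place of hydrogen on an aromatic carbon, next to the ring nitrogen and ortho to a large group. Among the compounds with values here, the one measured step lies elsewhere: compound 1 `CCc1ccccc1N(CC(=O)NCc1cccc(OC(F)(F)F)c1)S(=O)(=O)c1ccc(C)cc1` gives 427 nM in this assay, compound 2 `CCc1ccccc1N(CC(=O)NCc1ccccc1F)S(=O)(=O)c1ccc(C)cc1` gives 135 nM, and a 3.2-fold lower number from compound 1 to compound 2 (0.50 log units; beyond the scatter) changes the group on the amide side, not the pyridine. Within the data shown here, no measured step touches the change in compound 4. The expected step is a step that the limit leaves unreadable from compound 3 to compound 4, set without guidance from measured steps. Compound 4 is therefore estimated at 600 nM, with a range from 120 nM to 3000 nM.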

Compound 4, inhibition constant: 676 nM
The estimate for compound 4 lay 1.1-fold (0.05 log units) below the measured number, within the range that was stated.
By their numbers in this assay, from the lowest: compound 2; then compounds 1 and 4 (each within the scatter of the next).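

No step from compound 3 to compound 4 can be read, because the value of compound 3 is a limit and not a number: the limit of < 1450 nM in this assay, at which 1 of the 4 values shown sits.

The compounds shown leave open how far a methyl in place of hydrogen on this aromatic carbon shifts the inhibition constant.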